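Swapping the Aryl Group on a Thiazolidinone Core

This account rests on a few compounds, and the source may have more. Where it says the series, first, only, none or still open, it means among the compounds named here.

Compound 1 `O=C1CSC(c2cccc(F)c2)N1CCN1CCCCC1` and compound 2 `O=C1CSC(c2ccc(O)cc2)N1CCN1CCCCC1` share one core and differ only in the aryl group on a saturated ring carbon. In an ADME assay on Vero cells (Chlorocebus sabaeus) for cytotoxicity, read by neutral red uptake, tested at 98 ug/mL (on this read-out higher numbers stand for a weaker effect at the one concentration tested and lower numbers for a stronger effect), compound 1 gives 92%, and compound 2 gives 94%; the step of a number 2 percentage points higher from compound 1 to compound 2 (within the scatter) leaves the two side by side. Compound 3 `O=C1CSC(c2cccc(Cl)c2)N1CCN1CCCCC1` carries the change (3-chlorophenyl in place of 4-hydroxyphenyl on a saturated ring carbon). Going by the values given here, only the step from compound 1 to compound 2, a halophenyl-to-hydroxyphenyl exchange in the same place, bears on this, and it stayed within the scatter. Compound 3 is therefore expected to show no step beyond the scatter, a number 3 percentage points lower from compound 2 to compound 3 (within the scatter), with an estimate of 91% between 80% and 99%.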

Compound 3, a percentage reported as activity, at one concentration (the size of the read-out at that concentration, not a potency): 100%
The estimate for compound 3 lay 9 percentage points below the measured number; the whole stated range lies below it.
By their numbers in this assay, from the lowest: compounds 1, 2 and 3 (each within the scatter of the next).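

Exchanging 4-hydroxyphenyl for 3-chlorophenyl on the saturated ring carbon, which removes the hydrogen-bond donor and acceptor counted on the leaving group, gives a number 6 percentage points higher from compound 2 to compound 3 (within the scatter) in this assay and so stays inside the scatter. Chloro in place of fluoro on an aromatic carbon gives a number 8 percentage points higher from compound 1 to compound 3 (within the scatter) and also stays inside it, so all three aryl groups sit side by side at this position. Nothing available explains this result. On these data alone, whether an amine, a carboxylic acid or a longer chain on this carbon would stay side by side with these three remains open.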